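A few compounds are considered here, and "the series" means these few. Any claim that something is new, unique, unknown or untested is made for them only; others in the source may bear on it.

In an assay on HEK293 cells for positive allosteric modulation of metabotropic glutamate receptor 2 (Rattus norvegicus), read by thallium flux, with a stated time of 2.5 min (on this read-out higher numbers stand for an effect only at larger amounts of compound and lower numbers for an effect already at smaller amounts), the measured compounds gave these numbers:

Compound 1 `COc1cc(C(=O)O)ccc1OCCCCOc1ccc(C(=O)CC(C)C)c(O)c1C`: 40 nM
Compound 2 `Cc1c(OCCCCOc2ccc(C(=O)O)cc2)ccc(C(=O)CC(C)C)c1C`: "not determined" (no result reported)
Compound 3 `Cc1c(OCCCCOc2ccc(C(=O)O)cc2)ccc(C(=O)CC(C)C)c1O`: 122 nM

From the compounds shown here alone, compound 2 stands without a number in this assay, so its own level is unknown. Compound 4 `Cc1c(OCCCCOc2ccccc2C(=O)O)ccc(C(=O)CC(C)C)c1C` differs from compound 2 by 2-carboxyphenyl in place of 4-carboxyphenyl on an oxygen on a saturated carbon. Within the data shown here, the one measured step, a 3.1-fold higher number from compound 1 to compound 3 (0.48 log units; beyond the scatter), concerns the methoxy on the other ring of the shared core and leaves the carboxyphenyl end untouched. Among the measured compounds shown here, no measured step covers the present change, and compound 2 offers no anchor value. Compound 4 is therefore estimated at 600 nM in this assay, with a wide range from 80 nM to 6000 nM. A result that is only a limit is also held possible for compound 4.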

Compound 4, half-maximal effective concentration: 976 nM
For compound 4 the middle estimate is 1.6-fold (0.21 log units) below the measured one, and the stated range covers the measured number.
By their numbers in this assay, from the lowest: compound 1; then compound 3; then compound 4.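

Among these compounds, compound 2 has no number to set against compound 4, so no step between them can be read. The compounds shown leave open how 2-carboxyphenyl compares with 4-carboxyphenyl on this shared core. No evidence on the result is available.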